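From isopropoxy to methylsulfanyl on a shared core

The source may hold more compounds than are shown below. What is called first, only, known or untested is meant among the compounds shown, and "the series" means these compounds.

Three compounds have been measured in an ADME assay on the whole organism (Mus musculus, strain CD-1) for pharmacokinetics, at a dose of 10 mg/kg by the oral route (a lower number here means that a smaller share of the oral dose reaches the circulation, a higher number that a larger share of the oral dose reaches the circulation), so far:

- compound 1 `CCOc1cc([C@](O)(CCN(C)C)[C@@H](c2cc3cc(Br)ccc3nc2OC)c2cccc(OC)c2F)cc(OC)n1` gives 46%
- compound 2 `COc1cc([C@](O)(CCN(C)C)[C@@H](c2cc3cc(Br)ccc3nc2OC)c2cccc(OC)c2F)cc(OC(C)C)n1` gives 43%
- compound 3 `COc1cc([C@](O)(CCN(C)C)[C@@H](c2cc3cc(Br)ccc3nc2OC)c2ccnc(OC)c2OC)cc(OC(C)C)n1` gives 22%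

Among these, compound 2 stays within the scatter of compound 1 and lies beyond the scatter above compound 3. Compound 4 `COc1cc([C@](O)(CCN(C)C)[C@@H](c2cc3cc(Br)ccc3nc2OC)c2cccc(OC)c2F)cc(SC)n1` departs from compound 2 by a single change (methylsulfanyl in place of isopropoxy on an aromatic carbon) on an aromatic carbon of a six-membered aromatic ring with 1 nitrogen.

The nearest guide is a number 3 percentage points lower from compound 1 to compound 2 (within the scatter), which adds a methyl on a saturated chain carbon bound to an oxygen on an aromatic ring. The larger a number 21 percentage points lower from compound 2 to compound 3 (beyond the scatter) comes from replacing 2-fluoro-3-methoxyphenyl elsewhere in the molecule, so it bears only weakly here. For the measured compounds named here, no measured compound carries methylsulfanyl, which leaves the estimate loose.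

The estimated change is a number 3 percentage points lower from compound 2 to compound 4 (within the scatter), and no step beyond the scatter is expected. Compound 4 is expected at 40%, within an estimated range of 26% to 54%.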

Compound 4, oral bioavailability: 31%
Compound 4: the middle estimate sits 9 percentage points above what was measured; measured number inside the range.
By their numbers in this assay, from the lowest: compounds 3 and 4 (each within the scatter of the next); then compounds 2 and 1 (each within the scatter of the next).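

In this assay, for the compounds shown here, the earlier compounds showed this carbon, next to the ring nitrogen, only with ethoxy and isopropoxy, and those two stayed within the scatter of each other. Methylsulfanyl gives the first change here that lies beyond the scatter: a number 12 percentage points lower from compound 2 to compound 4 (beyond the scatter) and a number 15 percentage points lower from compound 1 to compound 4 (beyond the scatter), so the site is not indifferent to every replacement of these groups. The change alters the atom bound to the ring and the size of the group at once, and nothing given here accounts for the lower number.

The compounds shown leave open whether the sulfur or the smaller group goes with this step, which isopropylsulfanyl on the same carbon would help to separate. From the compounds shown here alone, how an amine such as dimethylamino would behave at this carbon also remains open.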